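Methylselanyl for methylsulfanyl on two thiophene-derived acylisothioureas

This account rests on a few compounds, and the source may have more. Where it says the series, first, only, none or still open, it means among the compounds named here.

Measured compounds:
- compound 1 `C[Se]/C(=N\C(=O)c1cc2ccccc2s1)NC(=O)c1cc2ccccc2s1`: > 100000 nM
- compound 2 `CS/C(=N\C(=O)c1sccc1Cl)NC(=O)c1sccc1Cl`: > 100000 nM
- compound 3 `CS/C(=N\C(=O)c1cc2ccccc2s1)NC(=O)c1cc2ccccc2s1`: 88200 nM

In a functional assay on HT-29 cells (Homo sapiens) for cytotoxicity, read by MTT assay, with a stated time of 72 h (a higher number here means that more compound is tolerated, a lower number that less compound is tolerated), compound 3 gives 88200 nM. For compound 1 the value > 100000 nM is a limit of this assay, not a number. For compound 2 the value > 100000 nM is likewise a limit. The change from compound 3 to compound 1 is a group of 2 heavy atoms (1 carbon, 1 selenium; no ring) in place of a group of 2 heavy atoms (1 carbon, 1 sulfur; no ring), on a carbon with a double bond to nitrogen; it brings an at least 1.1-fold higher number from compound 3 to compound 1 (0.05 log units; that floor lies within the scatter), and that step is bounded only by the limit of > 100000 nM in this assay, at which 2 of the 3 values shown sit.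

Compound 4 `C[Se]/C(=N\C(=O)c1sccc1Cl)NC(=O)c1sccc1Cl` is not yet measured. It arises from compound 2 by a group of 2 heavy atoms (1 carbon, 1 selenium; no ring) in place of a group of 2 heavy atoms (1 carbon, 1 sulfur; no ring), on a carbon with a double bond to nitrogen, the same change as from compound 3 to compound 1, with the same surroundings at the place. How the core of compound 2 differs from the core of compound 3 is not broken down here.

Compound 4 is expected to sit at or beyond the limit of this assay, because compound 2 already stands at > 100000 nM and the change from compound 3 to compound 1 gave an at least 1.1-fold higher number from compound 3 to compound 1 (0.05 log units; that floor lies within the scatter) rather than a lower number. The step from compound 2 to compound 4 in this assay is therefore estimated as a step that the limit leaves unreadable from compound 2 to compound 4. For compound 4 the expected value is 150000 nM, within 80000 nM to 400000 nM, and most probably reported only as a limit.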

Compound 4, concentration lethal to 50% of the cells: > 100000 nM
Compound 4 was reported as a limit (the forecaster's own chance of this, stated with the estimate: 85%); the middle value does not contradict the limit.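

No step can be read from compound 2 to compound 4 in this assay, since both compounds carry only a limit: the limit of > 100000 nM in this assay, at which 3 of the 4 values shown sit.

The compounds shown leave open whether putting the selenium-bearing group in place of methylsulfanyl changes the tolerated concentration on either core, as the only value that is not a limit is that of compound 3, 88200 nM.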